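This account rests on a few compounds, and the source may have more. Where it says the series, first, only, none or still open, it means among the compounds named here.

Compound 1 `CCN(CC)c1cc2[nH]c(C3CCCCC3)nc2cc1NC(=O)OCCOCCOC` in an ADME assay on Vero cells (Chlorocebus sabaeus) for cytotoxicity, read by resazurin assay, with a stated time of 3 days (a higher number here means a weaker inhibitor, a lower number a stronger inhibitor), gives > 100 ug/mL, which is a limit of the assay.
Compound 2 `CCN(CC)c1cc2[nH]c(C3CCCCC3)nc2cc1NC(=O)NCc1ccccc1` in this assay gives > 100 ug/mL, which is a limit of the assay.
Compound 3 `CCCc1ccc(C(=O)Nc2cc3nc(C4CCCCC4)[nH]c3cc2N(CC)CC)cc1` in this assay is recorded as "not determined" (no result reported).

Compound 3 thus has no number of its own in this assay. The two other results shown for the series both sit at a limit, which is where the limit of > 100 ug/mL in this assay, at which 2 of the 3 values shown sit, places them. Among the measured compounds shown here, the only step between measured compounds, a step that the two limits leave unreadable from compound 1 to compound 2, is bounded on both sides by limits, so its size cannot be read.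

Compound 4 `CCCNC(=O)Nc1cc2nc(C3CCCCC3)[nH]c2cc1N(CC)CC` differs from compound 3 by the change (propylamino in place of 4-propylphenyl on a carbonyl carbon). For the measured compounds named here, no measured step shares this change, and none of the measured steps gives a readable size at all. The evidence is therefore thin: what can be said is that the shared core with its diethylamino group and cyclohexyl group has, in the two cases where it was measured, not reached a number in this assay. The carbonyl-bearing side chain was varied in those two cases without a readable effect.

On that basis no step beyond the scatter is expected for compound 4 in this assay, and a further limit seems the most likely outcome. Compound 4 is estimated at 100 ug/mL, with a range from 40 ug/mL to 250 ug/mL.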

Compound 4, half-maximal inhibitory concentration: > 100 ug/mL
Compound 4: only a limit was reported (the forecaster's own chance of this, stated with the estimate: 75%); the middle value sits exactly at the limit.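

Compound 4, like compound 1 and compound 2, gives only a limit in this assay, so the steps from compound 1 and from compound 2 to compound 4 cannot be read: the limit of > 100 ug/mL in this assay, at which 3 of the 4 values shown sit.

The compounds shown leave open whether any group on the carbonyl carbon would bring the shared core to a number in this assay.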